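The source may hold more compounds than are shown below. What is called first, only, known or untested is meant among the compounds shown, and "the series" means these compounds.

Measured in a physicochemical assay for solubility, in phosphate buffer, with a stated time of 18 h, at pH 7; a lower number here means a less soluble compound, a higher number a more soluble compound:
- Compound 1 `Cc1ccc([C@@H]2[C@@H](C(=O)Nc3ccc(F)c(C#N)c3)c3ccccc3C(=O)N2CC(C)C)s1`: < 1000 nM
- Compound 2 `CC(C)CN1C(=O)c2ccccc2[C@H](C(=O)Nc2ccc(F)c(C#N)c2)[C@H]1c1cncc(C#N)c1`: 60000 nM

Compound 1 gives < 1000 nM, which is a limit of the assay and not a number. Going by the values given here, compound 2 gives 60000 nM, the only true number so far.

Compound 3 `CC(C)CN1C(=O)c2ccccc2[C@H](C(=O)Nc2ccc(F)c(C#N)c2)[C@H]1c1ccnnc1` is not yet measured. It differs from compound 2 in one place: pyridazin-4-yl in place of 5-cyanopyridin-3-yl on a saturated ring carbon. Here pyridazin-4-yl takes the place of 5-cyanopyridin-3-yl on a saturated ring carbon, next to the ring nitrogen.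

Among the compounds with values here, only one measured step bears on this change: an at least 60-fold higher number from compound 1 to compound 2 (1.77 log units; beyond the scatter). That step is large and starts from the limit of < 1000 nM in this assay, at which 1 of the 2 values shown sits. It shows that the group on this carbon can move the number a long way. Compound 3 keeps a six-membered aromatic ring with hetero atoms here, like compound 2 at 60000 nM, so a much smaller move is expected, perhaps slightly upward. The expected change is a 1.5-fold higher number from compound 2 to compound 3 (0.18 log units; within the scatter), and it is not expected to go beyond the scatter. Compound 3 is expected at 90000 nM, with an estimated range of 30000 nM to 200000 nM.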

Compound 3, solubility: 28000 nM
Beside the measured number, compound 3's estimate is 3.2-fold (0.51 log units) above it; the measured number lies below the stated range.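

In this assay, replacing 5-cyanopyridin-3-yl with pyridazin-4-yl on this saturated ring carbon gives a 2.1-fold lower number from compound 2 to compound 3 (0.33 log units; beyond the scatter), so even two similar six-membered aromatic rings with hetero atoms are not fully interchangeable here, although the step is only modest. Set against the 5-methylthiophen-2-yl group, pyridazin-4-yl gives an at least 28-fold higher number from compound 1 to compound 3 (1.44 log units; beyond the scatter), which means that a second group, and not only 5-cyanopyridin-3-yl, sits far from compound 1 in this assay. The value of compound 1 is a limit and not a number, so this step fixes only a minimum size: the limit of < 1000 nM in this assay, at which 1 of the 3 values shown sits.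

The step to pyridazin-4-yl loses a nitrile and changes the ring's hetero atoms at the same time, so the compounds shown cannot say which of the two accounts for it, and a plain pyridin-3-yl group would help to separate them. Also open, on these data alone, is how a phenyl ring without hetero atoms, an open-chain amine or a carboxylic acid on this carbon would compare with these values.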